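Piperidin-4-yl on the carbonyl carbon of compound 2

The source may report more compounds than this note shows. Statements on the series, on what has been measured and on what is new or still open speak of the compounds shown alone.

Among the measured compounds shown here, in a functional assay on a cell-free system (Platelet, plasma, Homo sapiens) for inhibition (on this read-out lower numbers stand for stronger inhibition and higher numbers for weaker inhibition), compound 2 `N=C(N)N1CCCC(C(=O)Nc2cccc(OCc3ccc(-c4ccccc4)cc3)c2)C1` gives 1000000 nM, the highest of the three numbers so far, with compound 1 `N=C(N)N1CCCC(C(=O)Nc2cccc(OCc3ccc(F)cc3)c2)C1` at 274000 nM. Compound 4 `O=C(Nc1cccc(OCc2ccc(-c3ccccc3)cc2)c1)C1CCNCC1` differs from compound 2 by a group of 6 heavy atoms (5 carbon, 1 nitrogen; one six-membered non-aromatic ring with 1 hetero atom) in place of a group of 9 heavy atoms (6 carbon, 3 nitrogen; one six-membered non-aromatic ring with 1 hetero atom), on a carbonyl carbon, on a carbonyl carbon. For the measured compounds named here, the one measured step, a 3.6-fold higher number from compound 1 to compound 2 (0.56 log units; beyond the scatter), lies at another place and does not test this change, though it is modest in size. Going by the values given here, the only guide to the entering group is compound 3 `O=C(Nc1ccc(OCc2ccc(F)cc2)cc1)C1CCNCC1`, which carries piperidin-4-yl and gives 121000 nM, but it differs from compound 4 elsewhere too. A modest move to a lower number is expected, and the estimated step is a 2.9-fold lower number from compound 2 to compound 4 (0.46 log units; beyond the scatter). For compound 4 the estimate is 350000 nM, with an expected range of 100000 nM to 1000000 nM.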

Compound 4, half-maximal inhibitory concentration: 111000 nM
Compound 4: the middle estimate sits 3.2-fold (0.50 log units) above what was measured, within the range that was stated.
By their numbers in this assay, from the lowest: compounds 4 and 3 (each within the scatter of the next); then compound 1; then compound 2.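

In this assay, the first change read directly on the carbonyl carbon, piperidin-4-yl in place of the larger nitrogen-richer group gives a 9.0-fold lower number from compound 2 to compound 4 (0.95 log units; beyond the scatter). This position therefore moves the number, and in this pair the group that leaves is not required for inhibition. No measurement at hand bears on the reason for this step.

On these data alone, whether the step carries over to the fluoro counterpart, compound 1, stays open. So does the reading on this carbonyl carbon of a carboxylic acid or an open-chain amine.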